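The compounds below may be only part of what the source reports. "The series", "measured", "known", "first", "only" and "open" are said of these compounds alone.

Measured compounds in an assay on cells for inhibition of Amine oxidase [flavin-containing] A (Homo sapiens), read by fluorescence and spectrophotometry, using microsomes, with a stated time of 20 min; a higher number here means a weaker inhibitor, a lower number a stronger inhibitor:
Compound 1 `NS(=O)(=O)c1ccc(-c2nnc(-c3ccc(Cl)c(Cl)c3)o2)cc1`: 46200 nM
Compound 2 `NS(=O)(=O)c1ccc(-c2nnc(-c3ccc(Cl)cc3)o2)cc1`: 68000 nM

Within the data shown here, compound 2 stands within the usual scatter of compound 1, the only other number in this assay; the step of a 1.5-fold higher number from compound 1 to compound 2 (0.17 log units; within the scatter) was too small to count as a real change. Compound 3 `NS(=O)(=O)c1ccc(-c2nnc(-c3ccccc3)o2)cc1` differs from compound 2 by hydrogen in place of chloro on an aromatic carbon. Among the measured compounds shown here, the one step that bears on this, a 1.5-fold higher number from compound 1 to compound 2 (0.17 log units; within the scatter), removed the same kind of group and stayed within the scatter, so compound 3 is expected to show a similarly small change, a 1.4-fold higher number from compound 2 to compound 3 (0.15 log units; within the scatter). Compound 3 is estimated at 95000 nM, in a range from 40000 nM to 250000 nM.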

Compound 3, half-maximal inhibitory concentration: 63900 nM
For compound 3 the middle estimate is 1.5-fold (0.17 log units) above the measured one, and the stated range covers the measured number.
By their numbers in this assay, from the lowest: compounds 1, 3 and 2 (each within the scatter of the next).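

In this assay, the swap of 4-chlorophenyl to phenyl gives a 1.1-fold lower number from compound 2 to compound 3 (0.03 log units; within the scatter), so the chloro on this aromatic carbon, para to a large group, can go without a step beyond the scatter. Compound 3 thus shows that the ring with no chloro at all still reads alike with compound 2. No evidence is available to explain this. Still open, from the compounds shown here alone, is whether a different group at this place, such as an amine, a methoxy group or a carboxylic acid, would give a step beyond the scatter.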